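Amide series: maximal response notes and one new analogue

The compounds below may be only part of what the source reports. "The series", "measured", "known", "first", "only" and "open" are said of these compounds alone.

Measured so far:
compound 1 `C=Cc1cccc(C(=O)NCN2CCC(c3cccc[n+]3[O-])CC2)c1` — 63%
compound 2 `Cc1ccc(Cl)c(NC(=O)CN2CCC(c3cccc[n+]3[O-])CC2)c1Cl` — 62%
compound 3 `COc1cccc(C)c1NC(=O)CN1CCC(c2cccc[n+]2[O-])CC1` — 56%

In a functional assay on HEK293 cells for agonist activity at D(4) dopamine receptor (Homo sapiens), read by FLIPR (a lower number here means a smaller maximal response, a higher number a larger maximal response), compound 1 gives 63%, the highest of the three numbers recorded. The nearest is compound 2 with 62%, a gap that lies within the scatter of this assay. The furthest is compound 3 with 56%, and that gap also lies within the scatter. The three measured compounds therefore cannot be ranked against one another; they sit in one band. Within the data shown here, no two of them differ in a single place, so no step between measured compounds is available to guide a prediction.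

Compound 4 `O=C(NCN1CCC(c2cccc[n+]2[O-])CC1)c1ccc(F)c(Cl)c1` is the new analogue. It differs from compound 1 by 3-chloro-4-fluorophenyl in place of 3-vinylphenyl on a carbonyl carbon. Among the measured compounds shown here, with no measured step that isolates a change on that carbonyl carbon, the only guide is the narrow band the three measured numbers occupy. The expectation is therefore a step of a number 3 percentage points lower from compound 1 to compound 4 (within the scatter) that does not go beyond the scatter in either direction. Compound 4 is estimated at 60%, with a range from 45% to 75%.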

Compound 4, largest response reached (reported as efficacy), in percent of the reference or control that the assay uses: 67%
Compound 4: the middle estimate sits 7 percentage points below what was measured; the range from low to high includes it.
By their numbers in this assay, from the lowest: compounds 3, 2, 1 and 4 (each within the scatter of the next, the first and the last beyond it).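

In this assay, among these compounds, 3-chloro-4-fluorophenyl in place of 3-vinylphenyl on a carbonyl carbon whose other neighbour is an amide-type nitrogen gives a number 4 percentage points higher from compound 1 to compound 4 (within the scatter) and is the first change that can be read in one place. This position therefore accepts an exchange of one substituted six-membered aromatic carbon ring for another with the same count of 8 heavy atoms, with the double bond outside the ring leaving and chlorine and fluorine entering, and the maximal response stays within the scatter. No supporting data bear on the origin of this outcome.

From the compounds shown here alone, a single pair of aryl groups with equal heavy-atom counts says little about how wide this tolerance is, so it remains open whether a saturated cyclohexyl ring, a phenyl ring carrying an amine or a carboxylic acid, or a longer chain on the same carbonyl carbon would keep the response in the same band. Also open, going by these compounds, is whether the same exchange would read the same way on the amide arrangement shared by compound 2 and compound 3.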